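The compounds below may be only part of what the source reports. "The series", "measured", "known", "first", "only" and "open" are said of these compounds alone.

Going by the values given here, in a functional assay on NCI-H460 cells (Homo sapiens) for inhibition, with a stated time of 72 h (a higher number here means a weaker inhibitor, a lower number a stronger inhibitor), compound 2 (`COc1ccc(S(=O)(=O)N2CCc3cccc(-c4ccc(F)c(F)c4)c32)cc1`) gives 46 nM, the lower of the two numbers so far, and compound 1 (`COc1ccc(S(=O)(=O)N2CCc3cccc(-c4ccc(N)cc4)c32)cc1`) gives 288 nM. Compound 3 (`COc1ccc(S(=O)(=O)N2CCc3cccc(-c4ccc(N(C)C)cc4)c32)cc1`) is still unmeasured. It differs from compound 2 as follows: 4-(dimethylamino)phenyl in place of 3,4-difluorophenyl on an aromatic carbon, with 4-(dimethylamino)phenyl in place of 3,4-difluorophenyl. Among the compounds with values here, only one measured step bears on this, a 6.3-fold lower number from compound 1 to compound 2 (0.80 log units; beyond the scatter), which replaced 4-aminophenyl with 3,4-difluorophenyl. The entering group is also an aminophenyl, so the number is expected to rise again, though perhaps not fully: the estimated step is a 3.7-fold higher number from compound 2 to compound 3 (0.57 log units; beyond the scatter) and lies in that direction. Compound 3 is expected at 170 nM (estimated range 50 nM to 550 nM).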

Compound 3, half-maximal inhibitory concentration: 556 nM
Beside the measured number, compound 3's estimate is 3.3-fold (0.51 log units) below it; measured number outside the range, above it.
By their numbers in this assay, from the lowest: compound 2; then compounds 1 and 3 (each within the scatter of the next).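

In this assay this position responds strongly to the group it carries: 4-(dimethylamino)phenyl in place of 3,4-difluorophenyl gives a 12-fold higher number from compound 2 to compound 3 (1.08 log units; beyond the scatter) and is a large step. Dimethylamino in place of amino gives only a 1.9-fold higher number from compound 1 to compound 3 (0.29 log units; within the scatter) and so makes no readable difference, which means both aminophenyl compounds sit well apart from the difluorophenyl one. Nothing available explains this gap.

Still open, on these data alone, is whether the gain needs both fluorines. A single fluorine, a plain phenyl or a 4-methoxyphenyl group at this position would help to show this.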